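One Added Methoxy on a Lone Measured Compound

The source may hold more compounds than are shown below. What is called first, only, known or untested is meant among the compounds shown, and "the series" means these compounds.

Going by the values given here, only one number anchors this small set. In a functional assay on HepG2 cells (Homo sapiens) for cytotoxicity, read by sulforhodamine B assay, with a stated time of 48 h (a lower number here means a stronger inhibitor, a higher number a weaker inhibitor), compound 2 (`COc1ccc(/C=C/C(=O)c2cccc(-c3cccc(F)c3)c2)cc1`) gives 1720 nM and stands alone, so it cannot yet be ranked against any neighbour. In this assay compound 1 (`COc1ccc(/C=C/C(=O)c2cccc(Br)c2)cc1OC`) gives "not determined" (no result reported) and therefore offers no comparison.

Compound 3 (`COc1ccc(/C=C/C(=O)c2cccc(-c3cccc(F)c3)c2)cc1OC`) differs from compound 2 in a single place (methoxy in place of hydrogen on an aromatic carbon), with methoxy in place of hydrogen on an aromatic carbon, ortho to a methoxy group. Among the compounds with values here, no pair of measured compounds here shows what such a change does. Within the data shown here, the only guide is compound 2 at 1720 nM in the same test, and no shift beyond the usual scatter of this assay is expected in either direction. The estimated step (a 1.1-fold lower number from compound 2 to compound 3 (0.06 log units; within the scatter)) is therefore small, and its direction is uncertain.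

A single measured value shows no trend, so the expected range has to stay wide. Compound 3 is estimated at 1500 nM with an expected range from 500 nM to 4500 nM once it has been tested.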

Compound 3, half-maximal inhibitory concentration: 1170 nM
For compound 3 the middle estimate is 1.3-fold (0.11 log units) above the measured one; low and high end bracket the measured number.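

In this assay, going by these compounds alone, this position now has its first measured pair, which reads as a 1.5-fold lower number from compound 2 to compound 3 (0.17 log units; within the scatter) and so gives a first direct look at what this change does. Adding a methoxy group to an aromatic carbon, ortho to a methoxy group, leaves compound 3 within the scatter of compound 2, so this pair shows neither a gain nor a loss in this test. The position can therefore carry a second methoxy group without a change that the assay can tell apart from repeat-to-repeat variation, although this rests on a single pair. No measurement at hand explains this result.

From the compounds shown here alone, whether the same holds for other groups at this place, such as a hydroxyl group, an amine, a carboxylic acid or a longer chain such as ethoxy, remains open. Going by these compounds, compound 1 has no number to compare, so it also remains open how its bromine, in the place of the fluorophenyl group of compound 3, would read in this test.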